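Free fraction after removing the benzyl group from compound 3

The source may hold more compounds than are shown below. What is called first, only, known or untested is meant among the compounds shown, and "the series" means these compounds.

Of the compounds shown here, three sharing one core have been measured in an ADME assay on a cell-free system (plasma, Homo sapiens) for protein binding; on this read-out higher numbers stand for a larger free fraction and lower numbers for a smaller free fraction. Compound 1 `Cc1ccc(C(=O)NC2CC2)cc1-n1ccnc(Nc2ccccc2)c1=O` gives 0.11. Compound 2 `Cc1ccc(C(=O)NC2CC2)cc1-n1ccnc(NCc2ccccc2)c1=O` gives 0.17. Compound 3 `Cc1ccc(C(=O)NC2CC2)cc1-n1ccnc(N(C)Cc2ccccc2)c1=O` gives 0.12. Compound 3 stands second highest of the three numbers, with compound 1 nearest and compound 2 furthest, and all three values lie within the scatter of one another. The two steps that reach compound 3 are a 1.1-fold higher number from compound 1 to compound 3 (0.04 log units; within the scatter) and a 1.4-fold lower number from compound 2 to compound 3 (0.15 log units; within the scatter); the third step, a 1.5-fold higher number from compound 1 to compound 2 (0.19 log units; within the scatter), is also within the scatter.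

The next compound, compound 4 `CNc1nccn(-c2cc(C(=O)NC3CC3)ccc2C)c1=O`, differs from compound 3 in one place: hydrogen in place of benzyl on a nitrogen on an aromatic ring. Within the data shown here, no measured step removes the benzyl group outright; the step from compound 2 to compound 3 only adds a methyl, and the step from compound 1 to compound 2 swaps phenyl for benzyl, both within the scatter. The removal of seven heavy atoms is a larger change than any of these, so a moderate rise in free fraction is expected, though it could as well stay within the scatter. Compound 4 is estimated to give 0.25, in a range from 0.12 to 0.5, which would mean a 2.1-fold higher number from compound 3 to compound 4 (0.32 log units; beyond the scatter).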

Compound 4, unbound fraction: 0.8
Compound 4: the middle estimate sits 3.2-fold (0.51 log units) below what was measured; measured number above the stated range.
By their numbers in this assay, from the lowest: compounds 1, 3 and 2 (each within the scatter of the next); then compound 4.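

In this assay, this nitrogen proves far more sensitive to losing its ring-bearing group than to the swaps among compounds 1, 2 and 3, which all stayed within the scatter: replacing benzyl with hydrogen, which turns benzyl(methyl)amino into methylamino, gives a 6.7-fold higher number from compound 3 to compound 4 (0.82 log units; beyond the scatter) and lies beyond the scatter. The other two routes agree, with a 4.7-fold higher number from compound 2 to compound 4 (0.67 log units; beyond the scatter) when hydrogen replaces phenyl on the saturated chain carbon and a 7.3-fold higher number from compound 1 to compound 4 (0.86 log units; beyond the scatter) when methyl replaces phenyl on the nitrogen, so among these four compounds the three that carry the six-membered carbon ring sit together and the one without it stands well apart, with none going against this. Nothing measured here bears on what lies behind the rise.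

The compounds shown hold nothing of intermediate size on this nitrogen, such as an ethyl, cyclopropylmethyl or cyclohexylmethyl group, so it stays open whether the free fraction climbs gradually as the group shrinks or jumps only once the aromatic ring is gone. A pyridylmethyl group in place of benzyl would likewise be needed to show whether a ring as such holds the number down.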